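A few compounds are considered here, and "the series" means these few. Any claim that something is new, unique, unknown or untested is made for them only; others in the source may bear on it.

Three compounds have been measured in an ADME assay on HepG2 2.2.15 cells (Homo sapiens) for cytotoxicity; a higher number here means that more compound is tolerated, a lower number that less compound is tolerated:

Compound 1 `O=c1[nH]c2ccc(Cl)cc2c(-c2ccccc2Cl)c1CCO`: 380000 nM
Compound 2 `CC(=O)OCCc1c(-c2ccccc2Cl)c2cc(Cl)ccc2[nH]c1=O`: 27000 nM
Compound 3 `N#CCC(=O)OCCc1c(-c2ccccc2Cl)c2cc(Cl)ccc2[nH]c1=O`: 100000 nM

Compound 3 stands second highest of the three, with compound 2 lower and compound 1 higher. Compound 4 `O=C(OCCc1c(-c2ccccc2Cl)c2cc(Cl)ccc2[nH]c1=O)C1CCCCC1` keeps the rest of compound 3 and has cyclohexyl in place of cyanomethyl on a carbonyl carbon.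

The closest measured precedent is a 3.7-fold higher number from compound 2 to compound 3 (0.57 log units; beyond the scatter), a modest step that also alters the group on this carbonyl carbon. Replacing hydrogen on the oxygen gave a 14-fold lower number from compound 1 to compound 2 (1.15 log units; beyond the scatter) with acetyl and a 3.8-fold lower number from compound 1 to compound 3 (0.58 log units; beyond the scatter) with (cyanomethyl)carbonyl. Both of these acylated compounds therefore lie below compound 1, and compound 3 is the higher of the two. Going by the values given here, no measured compound has a ring on this carbonyl carbon, so the size of the step remains uncertain.

Given a 3.7-fold higher number from compound 2 to compound 3 (0.57 log units; beyond the scatter), a modest step to a lower number is expected in this assay. The expected change is a 2.9-fold lower number from compound 3 to compound 4 (0.46 log units; beyond the scatter). Compound 4 is estimated at 35000 nM, with an expected range of 10000 nM to 110000 nM.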

Compound 4, half-maximal cytotoxic concentration: 38000 nM
Compound 4: the middle estimate sits 1.1-fold (0.04 log units) below what was measured; low and high end bracket the measured number.
By their numbers in this assay, from the lowest: compounds 2 and 4 (each within the scatter of the next); then compound 3; then compound 1.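

In this assay the ring on this carbonyl carbon places the ester with the acetyl ester and not with the cyanomethyl ester: cyclohexyl in place of cyanomethyl gives a clear step (a 2.6-fold lower number from compound 3 to compound 4 (0.42 log units; beyond the scatter)), whereas cyclohexyl in place of methyl does not leave the scatter (a 1.4-fold higher number from compound 2 to compound 4 (0.15 log units; within the scatter)). Going by these compounds alone, compound 3, with its nitrile, is thus the one acylated compound that stands apart from the other two. All three acylated compounds still lie below compound 1, and the cyclohexylcarbonyl group is no exception (a 10-fold lower number from compound 1 to compound 4 (1.00 log units; beyond the scatter)).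

What sets the cyanomethyl ester apart stays open, and no information at hand accounts for it.
A phenyl ring, a longer chain, an amine or a carboxylic acid on this carbonyl carbon would show whether compound 3 remains the exception.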